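The source may report more compounds than this note shows. Statements on the series, on what has been measured and on what is new or still open speak of the compounds shown alone.

Compound 1 `CCC(=O)Nc1cccc(S(=O)(=O)Oc2ccccc2C(C)C)c1` and compound 2 `CCCC(=O)Nc1cccc(S(=O)(=O)Oc2ccccc2C(C)C)c1` share one core. In a functional assay on M21 cells (Homo sapiens) for antiproliferative activity, read by sulforhodamine B assay, with a stated time of 48 h (a lower number here means a stronger inhibitor, a higher number a weaker inhibitor), compound 1 gives 25000 nM, and compound 2 gives 20000 nM. The change between them is methyl in place of hydrogen on a saturated chain carbon, two bonds along the chain from a carbonyl carbon, and the step is a 1.3-fold lower number from compound 1 to compound 2 (0.10 log units; within the scatter).

Compound 3 `CCNC(=O)Nc1ccc(S(=O)(=O)Oc2ccccc2C(C)C)cc1` sits on a different core; the difference between the two cores is not broken down here. In this assay compound 3 gives 4700 nM, the lowest number of the three measured.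

Compound 4 `CCCNC(=O)Nc1ccc(S(=O)(=O)Oc2ccccc2C(C)C)cc1` is not yet measured. It differs from compound 3 by methyl in place of hydrogen on a saturated chain carbon, two bonds along the chain from an amide-type nitrogen. Going by the values given here, this is the same kind of change as the one from compound 1 to compound 2, but the place differs: there it sat two bonds along the chain from a carbonyl carbon, here two bonds along the chain from an amide-type nitrogen. Given that the earlier step was a 1.3-fold lower number from compound 1 to compound 2 (0.10 log units; within the scatter), the step from compound 3 to compound 4 is expected to be a 1.2-fold lower number from compound 3 to compound 4 (0.07 log units; within the scatter). Compound 4 is therefore estimated at 4000 nM, with a range from 1500 nM to 10000 nM.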

Compound 4, half-maximal inhibitory concentration: 5100 nM
Compound 4: the middle estimate sits 1.3-fold (0.11 log units) below what was measured; the range from low to high includes it.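

In this assay the ethylamino to propylamino change gives a 1.1-fold higher number from compound 3 to compound 4 (0.04 log units; within the scatter), so on this core the added methyl leaves the number within the scatter. Set beside the earlier step, the same change shows no detectable difference between the two cores: the same change on two cores in this assay, a 1.3-fold lower number (0.10 log units; within the scatter) from compound 1 to compound 2 and a 1.1-fold higher number (0.04 log units; within the scatter) from compound 3 to compound 4, 1.4-fold (0.13 log units) apart, within the scatter of two such steps. Going by these compounds alone, this shows only that the step stays within the scatter in these two pairs; it gives no direction for the change and does not show that the step would stay this small on other cores.

As far as these compounds go, whether a longer chain, or a chain ending in an amine or a carboxylic acid, would behave the same on both cores stays open. From the compounds shown here alone, the contribution of the difference between the two cores themselves also remains open.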